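Pendant heteroaryl series: pyrimidine step from compound 3

A few compounds are considered here, and "the series" means these few. Any claim that something is new, unique, unknown or untested is made for them only; others in the source may bear on it.

Three compounds sharing one core differ only in the heteroaryl group on the saturated chain carbon bound to an oxygen on an aromatic ring and a saturated chain carbon. In an assay on HEK293 cells for inhibition of kynurenine 3-monooxygenase (Homo sapiens), read by LC-MS, with a stated time of 20 h (on this read-out lower numbers stand for stronger inhibition and higher numbers for weaker inhibition), compound 1 `C[C@@H](Oc1cc2oc(=O)n(CCC(=O)O)c2cc1Cl)c1ccc(Cl)cn1` gives 100 nM. Compound 2 `C[C@@H](Oc1cc2oc(=O)n(CCC(=O)O)c2cc1Cl)c1ncco1` gives 7940 nM in this assay, and compound 3 `Cc1ccnc([C@@H](C)Oc2cc3oc(=O)n(CCC(=O)O)c3cc2Cl)c1` gives 31600 nM. Compound 3 thus stands at the highest number of the three: the step of a 4.0-fold higher number from compound 2 to compound 3 (0.60 log units; beyond the scatter) is modest, whereas a 320-fold higher number from compound 1 to compound 3 (2.50 log units; beyond the scatter) is large, and a 79-fold higher number from compound 1 to compound 2 (1.90 log units; beyond the scatter) is large as well.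

The next step goes from compound 3 to compound 4 `C[C@@H](Oc1cc2oc(=O)n(CCC(=O)O)c2cc1Cl)c1ncccn1`: pyrimidin-2-yl in place of 4-methylpyridin-2-yl on a saturated chain carbon bound to an oxygen on an aromatic ring and a saturated chain carbon. Within the data shown here, no measured step exchanges a pyrimidin-2-yl group, so the only guides are the two steps already noted into compound 3. Both replacements of the 5-chloropyridin-2-yl group of compound 1 raised the number strongly, and the 1,3-oxazol-2-yl group of compound 2 sits between the two pyridines. Since compound 2 gives 7940 nM with an unsubstituted heteroaryl, compound 4 with its unsubstituted pyrimidin-2-yl is expected to fall nearer compound 2 than compound 1, a modest downward step a 2.6-fold lower number from compound 3 to compound 4 (0.42 log units; beyond the scatter) in this assay. Compound 4 is therefore estimated at 12000 nM, with a range from 3000 nM to 50000 nM.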

Compound 4, half-maximal inhibitory concentration in the kynurenine 3-monooxygenase assay: 3160 nM
Estimate against measurement, compound 4: 3.8-fold (0.58 log units) above; low and high end bracket the measured number.
By their numbers in the kynurenine 3-monooxygenase assay, from the lowest: compound 1; then compound 4; then compound 2; then compound 3.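

In the kynurenine 3-monooxygenase assay, pyrimidin-2-yl in place of 4-methylpyridin-2-yl on the saturated chain carbon gives a 10-fold lower number from compound 3 to compound 4 (1.00 log units; beyond the scatter), so this position responds strongly to a change that leaves a six-membered aromatic ring in place but alters its hetero atom count and its substitution. The pyrimidin-2-yl group also improves on the five-membered heteroaryl, with a 2.5-fold lower number from compound 2 to compound 4 (0.40 log units; beyond the scatter), yet it does not reach the 5-chloropyridin-2-yl group, with a 32-fold higher number from compound 1 to compound 4 (1.50 log units; beyond the scatter). In a physicochemical assay for permeability, using PAMPA (on this read-out higher numbers stand for higher permeability and lower numbers for lower permeability), compound 3 gives < 3 nm/s, which is a limit of the assay and not a number. In the physicochemical assay compound 4 gives < 3 nm/s, which is also a limit of the assay and not a number. In the physicochemical assay the step from compound 3 to compound 4 cannot be read, as both values are limits of the assay and not numbers: the limit of < 3 nm/s in the physicochemical assay, at which 2 of the 2 values shown sit.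

The change from compound 3 to compound 4 removes the methyl group and adds a ring nitrogen together, so the compounds shown leave open which of the two accounts for the lower number, and an unsubstituted pyridin-2-yl group would separate them. Also open, as far as these compounds go, is whether a 5-chloropyrimidin-2-yl group would approach compound 1 in the kynurenine 3-monooxygenase assay, and whether a methyl ester in place of the carboxylic acid would move the read-out of the physicochemical assay off its limit.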